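Halogen swap on the shared core: chloro to fluoro

This account rests on a few compounds, and the source may have more. Where it says the series, first, only, none or still open, it means among the compounds named here.

Compound 1, `Cc1ccc(C(=O)NC2CCCCCC2)c(=O)n1Cc1ccc(F)cc1`, in an assay on U-937 cells for inhibition of Fatty-acid amide hydrolase 1 (Homo sapiens), read by scintillation counting, with a stated time of 15 min (a higher number here means a weaker inhibitor, a lower number a stronger inhibitor), gives a limit of the assay, > 10000 nM.
Compound 2, `Cc1c(Br)cc(C(=O)NC2CCCCCC2)c(=O)n1Cc1ccc(F)cc1`, in this assay gives 5900 nM.
Compound 3, `Cc1c(Cl)cc(C(=O)NC2CCCCCC2)c(=O)n1Cc1ccc(F)cc1`, in this assay gives 5900 nM.

Compound 3 stands level with compound 2 at the digits shown, and the only other value is a limit, so it cannot be placed above or below compound 1 beyond that. The measured steps are small: an at least 1.6-fold lower number from compound 1 to compound 2 (0.22 log units; that floor lies within the scatter) and an at least 1.6-fold lower number from compound 1 to compound 3 (0.22 log units; that floor lies within the scatter) both start from a limit, as noted by the limit of > 10000 nM in this assay, at which 1 of the 3 values shown sits, and no change at the digits printed from compound 2 to compound 3 (within the scatter) shows no change. The change to compound 4, `Cc1c(F)cc(C(=O)NC2CCCCCC2)c(=O)n1Cc1ccc(F)cc1`, is fluoro in place of chloro on an aromatic carbon. It bears on the halogen steps measured so far, where bromo and chloro gave the same number, while the hydrogen compound gave only a limit. Compound 4 is therefore expected to sit near compound 3, with a step of a 1.4-fold higher number from compound 3 to compound 4 (0.13 log units; within the scatter) in this assay, leaning toward a weaker value, since fluoro is the smaller halogen and the limit of compound 1 lies close by. The estimate for compound 4 in this assay is 8000 nM, with a range from 4000 nM to 20000 nM.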

Compound 4, half-maximal inhibitory concentration: > 10000 nM
Compound 4 was reported as a limit; the forecaster's own chance of this, stated with the estimate: 35%; at least 1.2-fold (0.09 log units) between middle value and limit.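

In this assay compound 4 is reported only as a limit, which makes fluoro the one halogen of the three at this place, ortho to a methyl group, that yields no readable number. Fluoro in place of chloro gives an at least 1.6-fold higher number from compound 3 to compound 4 (0.22 log units; that floor lies within the scatter), and fluoro in place of bromo gives an at least 1.6-fold higher number from compound 2 to compound 4 (0.22 log units; that floor lies within the scatter), so both steps point the same way, yet neither floor is shown to pass the scatter. Where bromo and chloro alone had suggested that the halogens at this place read alike, fluoro instead joins the hydrogen compound at the limit, though the data cannot show how far beyond it either one lies: the limit of > 10000 nM in this assay, at which 2 of the 4 values shown sit.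

On these data alone, the step between the hydrogen compound and the fluoro compound cannot be read, as both ends are limits, so whether fluoro differs from hydrogen here remains unknown, and so does the true size of its steps from chloro and bromo. The compounds shown also leave open how this position would respond to a group other than a halogen, such as a methoxy group, an amine or a nitrile.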